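This account rests on a few compounds, and the source may have more. Where it says the series, first, only, none or still open, it means among the compounds named here.

In a physicochemical assay for lipophilicity (on this read-out higher numbers stand for higher lipophilicity and lower numbers for lower lipophilicity), compound 1 `CCCCCCCCCCCCNCCN` gives 4.69 and compound 2 `CCCCCCCCCCCCC(O)CNCCO` gives 4.69; the difference between these two cores is not broken down here. Compound 3 `CCCCCCCCCCNCCN` gives 2.71 in this assay, and the step of a number 1.98 log units lower from compound 1 to compound 3 (beyond the scatter) is made by the change (hydrogen in place of ethyl on a saturated chain carbon, ten or more bonds along the chain from an amine nitrogen). Compound 4 `CCCCCCCCCCC(O)CNCCO` has not been measured in this assay. It arises from compound 2 by the change (hydrogen in place of ethyl on a saturated chain carbon, ten or more bonds along the chain from an oxygen on a saturated carbon), which is the same kind of change, though the place is given with respect to an oxygen on a saturated carbon rather than an amine nitrogen. Because compound 1 moved to compound 3 by a number 1.98 log units lower from compound 1 to compound 3 (beyond the scatter), a step of similar size is expected from compound 2, a number 1.98 log units lower from compound 2 to compound 4 (beyond the scatter). Compound 4 is therefore estimated to give 2.71 in this assay, within 2.2 to 3.2.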

Compound 4, partition coefficient: 3.62
Compound 4: middle estimate off by 0.91 log units, on the low side; the measured number lies above the stated range.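

In this assay the change from ethyl to hydrogen gives a number 1.07 log units lower from compound 2 to compound 4 (beyond the scatter), set against a number 1.98 log units lower from compound 1 to compound 3 (beyond the scatter) on the other core. The direction therefore carries from one core to the other, but the size does not, and the step on the core of compound 2 is the smaller of the two. With one pair on each core, this describes these two cores only and gives no general rule for the change.

From the compounds shown here alone, whether a core bearing a carboxylic acid, or a longer chain, would give a step nearer one size or the other remains open. Nothing available bears on why the two steps differ in size.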